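Ortho substituent swap on the R-configured phenylethyl urea

The source may report more compounds than this note shows. Statements on the series, on what has been measured and on what is new or still open speak of the compounds shown alone.

Measured compounds:
- compound 1, `C[C@@H](NC(=O)Nc1ccccc1C(C)(C)C)c1ccccc1`: 17%
- compound 2, `C[C@H](NC(=O)Nc1ccccc1C(C)(C)C)c1ccccc1`: 100%
- compound 3, `CCCCCc1ccc(NC(=O)N[C@@H](C)c2ccccc2)cc1`: 93%

In an ADME assay on the whole organism with Oryza sativa as the target, tested at 10 uM (a lower number here means a stronger effect, a higher number a weaker effect of the compound at the concentration tested), compound 1 stands lowest of the three, with compound 3 nearest and compound 2 furthest. Among the measured compounds shown here, the only single-point step in this set is the configuration change a number 83 percentage points higher from compound 1 to compound 2 (beyond the scatter), a large step that is read against (the fact that compounds 1 and 2 differ only in the configuration as drawn). Compound 3 differs from compound 1 in more than one place, so its value is only noted, not interpreted as a step.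

Compound 4, `C[C@@H](NC(=O)Nc1ccccc1Br)c1ccccc1`, is not yet measured. It differs from compound 1 by bromo in place of tert-butyl on an aromatic carbon. For the measured compounds named here, no measured step touches a substituent change on this ring, so the configuration step gives no guide to direction here. The expectation therefore rests on compound 1 alone, with the ring change left open: a move upward from compound 1 is considered plausible but uncertain, so the estimated step is a number 28 percentage points higher from compound 1 to compound 4 (beyond the scatter). Compound 4 is expected to give about 45%, within a range from 15% to 90%.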

Compound 4, a percentage reported as activity, at one concentration (the size of the read-out at that concentration, not a potency): 94%
For compound 4 the middle estimate is 49 percentage points below the measured one, and the stated range ends below it.
By their numbers in this assay, from the lowest: compound 1; then compounds 3, 4 and 2 (each within the scatter of the next).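

In this assay, among the compounds shown here, bromo in place of tert-butyl on this aromatic carbon gives a number 77 percentage points higher from compound 1 to compound 4 (beyond the scatter) as the first substituent step at this position. The low number of compound 1 therefore depends on the tert-butyl group as well as on the configuration at the chain carbon, and a single change at either place removes it. Nothing measured on these compounds says why this exchange has so large an effect.

Still open, on these data alone, is whether other groups at this position, such as isopropyl, methyl or methoxy, would fall near compound 1 at 17% or near compound 4 at 94% in this assay. Also open, as far as these compounds go, is whether the opposite configuration of the bromo compound would shift the number at all.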